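The source may hold more compounds than are shown below. What is called first, only, known or untested is meant among the compounds shown, and "the series" means these compounds.

Measured so far in a functional assay on A-375 cells (Homo sapiens) for antiproliferative activity, read by CCK-8 assay, with a stated time of 72 h, tested at 8 uM; a higher number here means a stronger effect of the compound at the concentration tested, a lower number a weaker effect:
compound 1 `CC1CCCCN1C(=S)SCc1ccc(C(=O)Nc2ccccc2N)cc1` gives 85.2%
compound 2 `Nc1ccccc1NC(=O)c1ccc(CSC(=S)N2CCN(Cc3ccncc3)CC2)cc1` gives 89.5%
compound 3 `Nc1ccccc1NC(=O)c1ccc(CSC(=S)N2CCN(c3ccc(F)cc3)CC2)cc1` gives 76.3%

Compound 3 holds the lowest of the three numbers; its gap to compound 1 lies within the scatter, its gap to compound 2 beyond it. Compound 4 `Nc1ccccc1NC(=O)c1ccc(CSC(=S)N2CCN(Cc3cccnc3)CC2)cc1` differs from compound 3 by (pyridin-3-yl)methyl in place of 4-fluorophenyl on an amine nitrogen in a ring. Among the measured compounds shown here, the one measured step that bears on this change is a number 13.2 percentage points lower from compound 2 to compound 3 (beyond the scatter), where (pyridin-4-yl)methyl gave way to 4-fluorophenyl on an amine nitrogen in a ring. The present change runs the other way, with (pyridin-3-yl)methyl entering in place of 4-fluorophenyl, so a rise of roughly that size is expected, a number 10.7 percentage points higher from compound 3 to compound 4 (beyond the scatter). Compound 4 is accordingly estimated at 87%, with a range from 78% to 94%.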

Compound 4, a percentage reported as inhibition, at one concentration (the size of the read-out at that concentration, not a potency): 89.2%
Estimate against measurement, compound 4: 2.2 percentage points below; the measured number falls inside the stated range.
By their numbers in this assay, from the lowest: compounds 3, 1, 4 and 2 (each within the scatter of the next, the first and the last beyond it).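

In this assay the ring nitrogen of the pyridine can sit at either printed position without a change beyond the scatter, with a number 0.3 percentage points lower from compound 2 to compound 4 (within the scatter) as the pyridin-3-yl group replaces pyridin-4-yl. The second pyridine also gives a number 12.9 percentage points higher from compound 3 to compound 4 (beyond the scatter) in place of 4-fluorophenyl, so at this amine nitrogen the higher number is not tied to one pyridine isomer. Nothing at hand explains either step.

Going by these compounds, whether the higher number follows the pyridine nitrogen or the methyl link stays open. A benzyl group and a (pyridin-2-yl)methyl group on the same amine nitrogen would help separate the two.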